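The compounds below may be only part of what the source reports. "The series", "measured", "known", "first", "only" and "open" are said of these compounds alone.

Measured compounds:
compound 1 `Cc1noc(C)c1-c1ccc2c(c1)C(c1ccccc1)NC(=O)N2C` — 32.5%
compound 2 `Cc1nc(-c2ccccc2)sc1CN1C(=O)N(C)c2ccc(-c3c(C)noc3C)cc2C1c1ccccc1` — 29.2%
compound 3 `Cc1noc(C)c1-c1ccc2c(c1)C(c1ccccc1)N(Cc1nnc(-c3ccccc3)s1)C(=O)N2C` — 35.2%

In a functional assay on HepG2 cells (Homo sapiens) for inhibition, read by MTT assay, with a stated time of 48 h, tested at 2 uM (a lower number here means less inhibition, a higher number more inhibition at the concentration tested (going by the name of the read-out)), compound 3 gives 35.2%, the largest of the three numbers, but the steps of a number 2.7 percentage points higher from compound 1 to compound 3 (within the scatter) and a number 6 percentage points higher from compound 2 to compound 3 (within the scatter) both lie within the scatter, so no order among the three is established. Compound 4 `Cc1noc(C)c1-c1ccc2c(c1)C(c1ccccc1)N(Cc1nc(-c3ccccc3)cs1)C(=O)N2C` differs from compound 3 by 4-phenyl-1,3-thiazol-2-yl in place of 5-phenyl-1,3,4-thiadiazol-2-yl on a saturated chain carbon bound to an amide-type nitrogen in a ring. Among the measured compounds shown here, two measured steps bear on this place: attaching the whole group, a number 2.7 percentage points higher from compound 1 to compound 3 (within the scatter), and exchanging one heteroaryl for another there, a number 6 percentage points higher from compound 2 to compound 3 (within the scatter). Both are small. For the exchange to compound 4 no step beyond the scatter is therefore expected. Expected is a number 3.2 percentage points lower from compound 3 to compound 4 (within the scatter), nothing beyond the scatter. Compound 4 is estimated at 32%, with a range from 20% to 45%.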

Compound 4, a percentage reported as inhibition, at one concentration (the size of the read-out at that concentration, not a potency): 44.5%
Estimate against measurement, compound 4: 12.5 percentage points below; measured number inside the range.
By their numbers in this assay, from the lowest: compounds 2, 1, 3 and 4 (each within the scatter of the next, the first and the last beyond it).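

In this assay this place now yields steps beyond the scatter: (4-phenyl-1,3-thiazol-2-yl)methyl in place of hydrogen on the amide-type nitrogen in a ring (a number 12 percentage points higher from compound 1 to compound 4 (beyond the scatter)) and 4-phenyl-1,3-thiazol-2-yl in place of 4-methyl-2-phenyl-1,3-thiazol-5-yl (a number 15.3 percentage points higher from compound 2 to compound 4 (beyond the scatter)). The exchange of 5-phenyl-1,3,4-thiadiazol-2-yl for 4-phenyl-1,3-thiazol-2-yl (a number 9.3 percentage points higher from compound 3 to compound 4 (within the scatter)) stays within the scatter, so compound 3 and compound 4 remain unseparated. Nothing shown accounts for these differences.

Open, as far as these compounds go, is whether a longer chain carrying the 4-phenyl-1,3-thiazol-2-yl group, or an amine or carboxylic acid on its phenyl ring, would shift the number. From the compounds shown here alone, with one concentration only, potency also stays open.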